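The compounds below may be only part of what the source reports. "The series", "measured", "known", "first", "only" and "open" are said of these compounds alone.

Measured so far in a functional assay on HCT-116 cells (Homo sapiens) for antiproliferative activity, read by MTT assay, with a stated time of 72 h; on this read-out lower numbers stand for stronger inhibition and higher numbers for weaker inhibition:

Compound 1 `COc1ccc(NC(=S)Nc2nc(C(=O)NCCCc3ccccc3)cs2)cc1` gives 44800 nM
Compound 2 `O=C(NCc1ccccc1)c1csc(NC(=S)Nc2ccc(Cl)cc2)n1` gives 62200 nM
Compound 3 `CCOC(=O)c1csc2nc(CN3CCN(C)CC3)c(-c3ccc(C)cc3)n12` gives 61000 nM

Compound 3 at 61000 nM stands within the scatter of both compound 1 and compound 2, so the three values do not separate in this assay, even though the core of compound 3 differs from the core shared by the other two.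

The next compound is compound 4 `CCOC(=O)c1csc2nc(CN3CCN(Cc4ccccc4)CC3)c(-c3ccc(C)cc3)n12`, with the change (phenyl in place of hydrogen on a saturated chain carbon bound to an amine nitrogen in a ring). This places phenyl in place of hydrogen on a saturated chain carbon bound to an amine nitrogen in a ring, which also reads as methyl to benzyl. Within the data shown here, no measured pair shows this change, so the direction is only a weak expectation. A modest move towards a lower number is expected, with the size staying inside the scatter or close to its edge. The expected step is a 1.6-fold lower number from compound 3 to compound 4 (0.21 log units; within the scatter) in this assay. For compound 4 the estimated value is 38000 nM with an expected range from 12000 nM to 90000 nM in this read-out.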

Compound 4, half-maximal inhibitory concentration: 47800 nM
For compound 4 the middle estimate is 1.3-fold (0.10 log units) below the measured one, and the stated range covers the measured number.
By their numbers in this assay, from the lowest: compounds 1, 4, 3 and 2 (each within the scatter of the next).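

Among these compounds, this is the first pair that differs in one place only: phenyl in place of hydrogen on a saturated chain carbon bound to an amine nitrogen in a ring, which also reads as methyl to benzyl. In this assay the pair shows a 1.3-fold lower number from compound 3 to compound 4 (0.11 log units; within the scatter), so at this position the phenyl brings no change that separates from the scatter in either direction. No measured evidence bearing on this result is available.

Among the compounds shown here, only this one change can be read at this position, so it remains open whether a basic amine or a longer chain there would move the value beyond the scatter. The ethyl ester has no one-place partner either, which leaves open what a carboxylic acid in its place would do.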